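The compounds below may be only part of what the source reports. "The series", "measured", "known", "first", "only" and "open" are said of these compounds alone.

Working notes on the aryl-quinolinyl thiosemicarbazone series, read in a functional assay on HeLa cells (Homo sapiens) for antiproliferative activity, read by sulforhodamine B assay, with a stated time of 72 h; on this read-out higher numbers stand for weaker inhibition and lower numbers for stronger inhibition.

Compound 1 `Fc1cccc(NC(=S)N/N=C/c2ccc3ccccc3n2)c1` gives 70100 nM. Compound 2 `Cc1cccc(NC(=S)N/N=C/c2ccc3ccccc3n2)c1` returns only a limit in this assay, > 100000 nM, which is the limit of > 100000 nM in this assay, at which 1 of the 3 values shown sits. Compound 3 `S=C(NCc1ccccc1)N/N=C/c1ccc2ccccc2n1` gives 62800 nM. Among the two numbers actually reported, compound 3 has the lowest, but its nearest neighbour is compound 1, and the step of a 1.1-fold lower number from compound 1 to compound 3 (0.05 log units; within the scatter) lies within the scatter, so the two cannot be ordered. The step of an at least 1.5-fold lower number from compound 2 to compound 3 (0.20 log units; that floor lies within the scatter) is a floor set by the limit and also sits within the scatter, as does an at least 1.4-fold higher number from compound 1 to compound 2 (0.15 log units; that floor lies within the scatter).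

Compound 4 `COc1ccc(NC(=S)N/N=C/c2ccc3ccccc3n2)cc1` differs from compound 3 by 4-methoxyphenyl in place of benzyl on an amide-type nitrogen. Going by the values given here, the steps that bear on this exchange at the amide-type nitrogen are a 1.1-fold lower number from compound 1 to compound 3 (0.05 log units; within the scatter) and an at least 1.5-fold lower number from compound 2 to compound 3 (0.20 log units; that floor lies within the scatter), both replacing an aryl group with benzyl, and neither moved this assay beyond the scatter. Among the compounds with values here, no step in this assay exceeds the scatter at all. A step in this assay of no more than the scatter is therefore expected, in no particular direction, so the expected step is a 1.1-fold higher number from compound 3 to compound 4 (0.06 log units; within the scatter).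

The expected value for compound 4 in this assay is 72000 nM, ranging from 30000 nM to 150000 nM.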

Compound 4, half-maximal inhibitory concentration: 72600 nM
Estimate against measurement, compound 4: 1.0-fold (0.00 log units) below; measured number inside the range.
By their numbers in this assay, from the lowest: compounds 3, 1 and 4 (each within the scatter of the next). At a limit, above all of these: compound 2.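

In this assay, 4-methoxyphenyl in place of benzyl on the amide-type nitrogen gives a 1.2-fold higher number from compound 3 to compound 4 (0.06 log units; within the scatter), and the same group in place of 3-fluorophenyl gives a 1.0-fold higher number from compound 1 to compound 4 (0.02 log units; within the scatter). Compound 4 thus brings the first oxygen-bearing group shown at this nitrogen, and neither exchange moves the number beyond the scatter, so compounds 1, 3 and 4 cannot be ordered and the series stays flat at this position across a benzyl and two substituted phenyl groups. The comparison with compound 2 gives only a floor, an at least 1.3-fold lower number from compound 2 to compound 4 (0.13 log units; that floor lies within the scatter), and compound 2 is a limit, not a number: the limit of > 100000 nM in this assay, at which 1 of the 4 values shown sits.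

The compounds shown leave open whether any group on this nitrogen can move the number beyond the scatter, since a basic amine such as a dimethylamino group, a carboxylic acid or a longer chain such as phenethyl does not appear among them. They also leave open whether the flatness belongs to this nitrogen alone, since all four compounds share the same core and so say nothing of a change made elsewhere.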